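Pyridin-2-yl replaces phenyl on the sulfonyl of compound 3

This account rests on a few compounds, and the source may have more. Where it says the series, first, only, none or still open, it means among the compounds named here.

Compound 1 `CNCc1cc(-c2ccccc2)n(S(=O)(=O)c2ccc(C)cc2)c1`: 66%
Compound 2 `CNCc1cc(-c2cccnc2)n(S(=O)(=O)c2ccccc2)c1`: 4%
Compound 3 `CNCc1cc(-c2cccnc2F)n(S(=O)(=O)c2ccccc2)c1`: 99%

Of the compounds shown here, three share one core and have been tested in a functional assay on the whole organism (strain Jcl:SD) for inhibition, with Rattus norvegicus as the target, with stated times of 3 min and 3 h, at a dose of 1 mg/kg by the intravenous route; a higher number here means more inhibition at the dose given (going by the name of the read-out), a lower number less inhibition. Compound 1 gives 66%. Compound 2 gives 4%, and compound 3 gives 99%. Compound 3 stands highest of the three; the nearest is compound 1, beyond the scatter below it, and compound 2 lies furthest, far below it. The single one-place step shown is a number 95 percentage points higher from compound 2 to compound 3 (beyond the scatter), and it concerns a fluoro on an aromatic carbon of the ring attached to the core, not the sulfonyl substituent.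

Compound 4 `CNCc1cc(-c2cccnc2F)n(S(=O)(=O)c2ccccn2)c1` differs from compound 3 in one place: pyridin-2-yl in place of phenyl on a sulfonyl sulfur. Among the measured compounds shown here, no measured step touches the sulfonyl aryl group; compounds 1 and 2 differ there but also elsewhere, so their values cannot be separated into a single change. The data therefore give no direct guide, and compound 3 already sits near the top of what this read-out can report.

With that in mind, compound 4 is expected to remain strongly inhibiting, with a step of a number 14 percentage points lower from compound 3 to compound 4 (beyond the scatter) estimated, mostly reflecting the ceiling. The estimate for compound 4 is 85%, in a range from 50% to 100%.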

Compound 4, a percentage reported as inhibition, in the whole organism at one dose (the size of the read-out at that dose, not a potency) in the Rattus norvegicus assay: 81%
The estimate for compound 4 lay 4 percentage points above the measured number, within the range that was stated.
By their numbers in the Rattus norvegicus assay, from the lowest: compound 2; then compound 1; then compound 4; then compound 3.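

Among the compounds shown here, in the Rattus norvegicus assay, this is the first reading of the sulfonyl aryl group as a single change: with pyridin-2-yl in place of phenyl on the sulfonyl sulfur, the step is a number 18 percentage points lower from compound 3 to compound 4 (beyond the scatter), so this place does respond to the exchange, though compound 4 keeps most of the inhibition. In a physicochemical assay for lipophilicity, read by HPLC, at pH 7.4 (a lower number here means a more polar compound, a higher number a more lipophilic compound), compound 3 gives -0.09 and compound 4 gives 0.05, with the step being a number 0.14 log units higher from compound 3 to compound 4 (within the scatter), so the pair separates on inhibition but not on this distribution coefficient. Nothing measured here accounts for the lower inhibition of compound 4.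

For the compounds shown here, whether a thiophen-2-yl ring or a plain methyl group on the sulfonyl sulfur would keep the inhibition of compound 3 remains open, since phenyl and pyridin-2-yl are the only two groups compared there on an otherwise identical structure. On these data alone, this exchange is also read only once, in the presence of the fluoro group, so whether it would give a step of similar size on the structure of compound 2, which lacks that fluoro, stays unknown.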